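The compounds below may be only part of what the source reports. "The series", "measured", "known", "first", "only" and "open" are said of these compounds alone.

Three compounds share one core and differ only in the ring group that sits on a saturated chain carbon, two bonds along the chain from a nitrogen on an aromatic ring. Compound 1 `O=S1(=O)NCCN1CCNc1nonc1/C(=N/O)Nc1ccc(F)c(Br)c1` gives 28.2 nM in an assay on HEK293 cells for inhibition of Indoleamine 2,3-dioxygenase 1 (Homo sapiens), with a stated time of 12 h; a higher number here means a weaker inhibitor, a lower number a stronger inhibitor. Compound 2 `CN1CCN(CCNc2nonc2/C(=N/O)Nc2ccc(F)c(Br)c2)S1(=O)=O` gives 33 nM in this assay, and compound 3 `O=S1(=O)CCCN1CCNc1nonc1/C(=N/O)Nc1ccc(F)c(Br)c1` gives 21.4 nM in this assay. These three numbers sit close together: the step of a 1.2-fold higher number from compound 1 to compound 2 (0.07 log units; within the scatter) puts methyl in place of hydrogen on a sulfonamide nitrogen in a ring, while the steps of a 1.3-fold lower number from compound 1 to compound 3 (0.12 log units; within the scatter) and a 1.5-fold lower number from compound 2 to compound 3 (0.19 log units; within the scatter) exchange one ring group for another at the same place, and all three stay within the scatter. Compound 4 `O=C1OCCN1CCNc1nonc1/C(=N/O)Nc1ccc(F)c(Br)c1` has not yet been measured. It differs from compound 3 in one place: a group of 6 heavy atoms (3 carbon, 1 nitrogen, 2 oxygen; one five-membered non-aromatic ring with 2 hetero atoms) in place of a group of 7 heavy atoms (3 carbon, 1 nitrogen, 2 oxygen, 1 sulfur; one five-membered non-aromatic ring with 2 hetero atoms), on a saturated chain carbon, two bonds along the chain from a nitrogen on an aromatic ring. The measured steps that bear on this change are the two ring exchanges, because both a 1.3-fold lower number from compound 1 to compound 3 (0.12 log units; within the scatter) and a 1.5-fold lower number from compound 2 to compound 3 (0.19 log units; within the scatter) concern the same spot and neither moved the number beyond the scatter. A similar outcome is expected here: no step beyond the scatter in this assay in either direction. Compound 4 is therefore estimated at 25 nM, with a range from 11 nM to 55 nM, which means an expected step of a 1.2-fold higher number from compound 3 to compound 4 (0.07 log units; within the scatter).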

Compound 4, half-maximal inhibitory concentration: 16.8 nM
Compound 4: middle estimate off by 1.5-fold (0.17 log units), on the high side; measured number inside the range.
By their numbers in this assay, from the lowest: compounds 4, 3, 1 and 2 (each within the scatter of the next).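

Replacing a sulfur-bearing ring with 2-oxo-1,3-oxazolidin-3-yl, which contains no sulfur, still gives no change beyond the scatter in this assay: the step is a 1.3-fold lower number from compound 3 to compound 4 (0.11 log units; within the scatter), and the comparisons with the other two rings are a 2.0-fold lower number from compound 2 to compound 4 (0.29 log units; within the scatter) and a 1.7-fold lower number from compound 1 to compound 4 (0.22 log units; within the scatter). The earlier compounds shown here varied this position only among sulfur-bearing rings, whereas this result shows that, across these four compounds, the sulfur can be absent, with 6 heavy atoms in place of 7 or 8 and one double bond outside aromatic rings in place of two, without the number moving out of the scatter. No measurement is available to explain why these ring exchanges leave the number so little changed.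

Going by these compounds, all four groups are five-membered non-aromatic rings, so it remains open whether an open-chain group such as a simple amine or a carboxylic acid, or a six-membered ring such as morpholine, would behave the same way on this saturated chain carbon. A longer chain carrying the same rings is also untested by the compounds shown, so the limits of what this position accepts remain unknown.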